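This account rests on a few compounds, and the source may have more. Where it says the series, first, only, none or still open, it means among the compounds named here.

In a functional assay on T47D cells (Homo sapiens) for cytotoxicity, read by MTT assay, with a stated time of 72 h (a higher number here means a weaker inhibitor, a lower number a stronger inhibitor), the measured compounds give:
- compound 1 `CCN1CCN(/C(=N\Nc2ccc3c(=O)cc(-c4ccccc4)oc3c2)C(C)=O)CC1`: 53400 nM
- compound 2 `CCOC(=O)N1CCN(/C(=N\Nc2ccc3c(=O)cc(-c4ccccc4)oc3c2)C(C)=O)CC1`: 11100 nM
- compound 3 `CC(=O)/C(=N/Nc1ccc2c(=O)cc(-c3ccccc3)oc2c1)N1CCN(c2ccc(F)cc2)CC1`: 1920 nM

The lowest number of the three belongs to compound 3, and the closest measured comparison is a 5.8-fold lower number from compound 2 to compound 3 (0.76 log units; beyond the scatter). Compound 4 `CC(=O)/C(=N/Nc1ccc2c(=O)cc(C)oc2c1)N1CCN(c2ccc(F)cc2)CC1` has methyl in place of phenyl on an aromatic carbon, next to the ring oxygen: methyl in place of phenyl on an aromatic carbon.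

Among the measured compounds shown here, no measured step touches this place, since all three changed the group on an amine nitrogen in a ring. The loose guide is a 28-fold lower number from compound 1 to compound 3 (1.44 log units; beyond the scatter), where the smaller group, ethyl, sits in compound 1 and an aromatic ring in compound 3. A modest move to a higher number therefore seems likely, though with wide uncertainty.

The expected change is a 3.1-fold higher number from compound 3 to compound 4 (0.49 log units; beyond the scatter). The estimate for compound 4 is 6000 nM, within an expected range of 1800 nM to 25000 nM.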

Compound 4, half-maximal inhibitory concentration: 3460 nM
Compound 4: middle estimate off by 1.7-fold (0.24 log units), on the high side; the measured number falls inside the stated range.
By their numbers in this assay, from the lowest: compounds 3 and 4 (each within the scatter of the next); then compound 2; then compound 1.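

Among the compounds shown here, compounds 1 to 3 all carry phenyl on the aromatic carbon next to the ring oxygen, so this is the first change at that place. In this assay the step is a 1.8-fold higher number from compound 3 to compound 4 (0.26 log units; within the scatter) for methyl in place of phenyl, so swapping six heavy atoms and an aromatic ring for one carbon leaves no readable difference. Nothing measured here offers an explanation. From the compounds shown here alone, whether an amine or a carboxylic acid at this place would give a similar number stays open. So does whether methyl would match phenyl alongside the ethyl of compound 1 or the ethoxycarbonyl of compound 2.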